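A few compounds are considered here, and "the series" means these few. Any claim that something is new, unique, unknown or untested is made for them only; others in the source may bear on it.

Among the two measured compounds, compound 2 `O=C(O)Cc1sc(C(c2ccc(F)cc2)c2ccc(F)cc2)nc1-c1cn[nH]c1` stands at the higher, weaker end in an in vitro functional assay on HEK285-7 cells for antagonist activity at prostaglandin D2 receptor 2 (Homo sapiens), read by BRET and beta-arrestin recruitment; on this read-out lower numbers stand for stronger inhibition and higher numbers for weaker inhibition: compound 2 gives 220 nM, while compound 1 `O=C(O)Cc1sc(C(c2ccccc2)c2ccc(O)cc2)nc1-c1ccc(F)cc1` gives 30 nM, a gap beyond the usual scatter of this assay. Compound 2 thus sets the starting point for the next step, which is the untested compound 3 `Nc1cc(-c2nc(C(c3ccc(F)cc3)c3ccc(F)cc3)sc2CC(=O)O)cc(F)n1`. The difference between the two is a single exchange on the shared core, namely 2-amino-6-fluoropyridin-4-yl in place of 1H-pyrazol-4-yl on an aromatic carbon: a five-membered aromatic ring with 2 hetero atoms gives way to a six-membered aromatic ring with 1 hetero atom that carries an amino group and a fluorine. Among the measured compounds shown here, no pair of measured compounds shows this particular exchange, so its effect has to be estimated rather than read off. For compound 3 a moderate step toward stronger inhibition is expected, a 2.2-fold lower number from compound 2 to compound 3 (0.34 log units; beyond the scatter), with considerable uncertainty in either direction. Compound 3 is therefore estimated to reach about 100 nM in this assay, with a likely range from 30 nM to 400 nM.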

Compound 3, half-maximal inhibitory concentration: 1400 nM
The estimate for compound 3 lay 14-fold (1.15 log units) below the measured number, outside the stated range (above it).
By their numbers in this assay, from the lowest: compound 1; then compound 2; then compound 3.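

In this assay, putting 2-amino-6-fluoropyridin-4-yl in place of 1H-pyrazol-4-yl on this aromatic carbon, next to the ring nitrogen and next to the ring atom that bears the carboxymethyl group, gives a 6.4-fold higher number from compound 2 to compound 3 (0.80 log units; beyond the scatter), so inhibition becomes weaker. Among the compounds shown here, this is the first direct sign that the group at this position affects inhibition, since compound 2 and compound 3 differ only here, and the change is large enough to stand clear of ordinary assay variation. The exchange alters the ring size, the number of ring hetero atoms and the attached groups all at once, and nothing available explains why the number rose or which of these alterations matters.

Still open, from the compounds shown here alone, is how much of the loss belongs to the six-membered ring itself and how much to the amino group or the fluorine, a question that a plain pyridin-4-yl, a 2-aminopyridin-4-yl and a 2-fluoropyridin-4-yl at the same position could help to separate. Going by these compounds, it is also open whether a smaller change to the five-membered ring, such as a methyl group on the pyrazole nitrogen, would shift inhibition in either direction.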